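Dropping the trifluoromethyl from compound 2

A few compounds are considered here, and "the series" means these few. Any claim that something is new, unique, unknown or untested is made for them only; others in the source may bear on it.

Of the compounds shown here, two sharing one core have so far been tested in an ADME assay on L6 cells (Rattus norvegicus) for cytotoxicity, read by resazurin assay, with a stated time of 72 h; a higher number here means that more compound is needed for the effect, a lower number that less compound is needed. Compound 1 `CCOC(=O)C1=C(C)N/C(=C/c2cc(C)n(-c3ccc(N(C)C)cc3)c2C)C1=O` gives 180000 nM. Compound 2 `CCOC(=O)C1=C(C)N/C(=C/c2cc(C)n(Cc3ccc(C(F)(F)F)cc3)c2C)C1=O` gives 72000 nM in this assay, the lowest of the two numbers, with compound 1 standing a step above it that lies beyond the usual scatter. The third member, compound 3 `CCOC(=O)C1=C(C)N/C(=C/c2cc(C)n(Cc3ccccc3)c2C)C1=O`, has not yet been measured. It differs from compound 2 by hydrogen in place of trifluoromethyl on an aromatic carbon, para to a large group. Among the measured compounds shown here, no measured pair shows this exact change, so the size of the step is open. For the measured compounds named here, with only two numbers to draw on, a modest move toward a higher number, or none beyond the scatter, is the expectation, and compound 3 is estimated at 110000 nM, within a range from 45000 nM to 270000 nM. That expectation corresponds to a 1.5-fold higher number from compound 2 to compound 3 (0.18 log units; within the scatter).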

Compound 3, half-maximal effective concentration in the L6 assay: 50000 nM
Compound 3: middle estimate off by 2.2-fold (0.34 log units), on the high side; measured number inside the range.
By their numbers in the L6 assay, from the lowest: compounds 3 and 2 (each within the scatter of the next); then compound 1.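

In the L6 assay, compound 2 gives 72000 nM and compound 3 gives 50000 nM; hydrogen in place of trifluoromethyl on the aromatic carbon gives a 1.4-fold lower number from compound 2 to compound 3 (0.16 log units; within the scatter), which means that removing this group has no readable effect on the number here. The exchange on the aromatic nitrogen, benzyl in place of 4-(dimethylamino)phenyl, gives a 3.6-fold lower number from compound 1 to compound 3 (0.56 log units; beyond the scatter) and is a modest step, so among the single changes shown, only this one is readable. Nothing available explains either step. In a physicochemical assay for lipophilicity, read by HPLC, at pH 7.4 (a lower number here means a more polar compound, a higher number a more lipophilic compound), compound 2 gives "not determined" (no result reported) and compound 3 gives "not determined" (no result reported), so no comparison can be made there.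

On these data alone, it remains open whether a carboxylic acid or an amine on that aromatic carbon would move the number in the L6 assay beyond the scatter. As far as these compounds go, it is equally open how a longer chain between the aromatic nitrogen and the phenyl ring would read.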